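Swapping Chloro for Azido on the Weaker Core

The source may report more compounds than this note shows. Statements on the series, on what has been measured and on what is new or still open speak of the compounds shown alone.

Compound 1 `COc1ccc(N(Cc2cc(OC)c(OC)c(OC)c2)C(=O)CCl)cc1O` and compound 2 `COc1ccc(CN(C(=O)CCl)c2cc(OC)c(OC)c(OC)c2)cc1O` are made of the same atoms joined differently; the difference between the two cores is not broken down here. In a functional assay on HCT-116 cells (Homo sapiens) for inhibition, read by MTT assay, with a stated time of 48 h (on this read-out lower numbers stand for stronger inhibition and higher numbers for weaker inhibition), compound 1 gives 22500 nM, the highest number of the three measured compounds, while compound 2 gives 250 nM. Compound 3 `COc1ccc(CN(C(=O)CN=[N+]=[N-])c2cc(OC)c(OC)c(OC)c2)cc1O` keeps the core of compound 2 with a single change, (azido in place of chloro on a saturated chain carbon bound to a carbonyl carbon). That change produced a 1.6-fold higher number from compound 2 to compound 3 (0.21 log units; within the scatter), and in this assay compound 3 gives 410 nM.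

Compound 4 `COc1ccc(N(Cc2cc(OC)c(OC)c(OC)c2)C(=O)CN=[N+]=[N-])cc1O` carries the same change over to the core of compound 1: the difference from compound 1 to compound 4 is azido in place of chloro on a saturated chain carbon bound to a carbonyl carbon. The place of the change reads the same in both cases, so this is the same change repeated on another core. Among the compounds with values here, whether the two cores respond alike to it is not known from these compounds; the only guide is the one earlier step. On that basis compound 4 is expected to show a step of a 1.5-fold higher number from compound 1 to compound 4 (0.18 log units; within the scatter), resting on a 1.6-fold higher number from compound 2 to compound 3 (0.21 log units; within the scatter). In this assay compound 4 is therefore estimated at about 34000 nM. Within the data shown here, the estimate for compound 4 is expected to fall between 13000 nM and 90000 nM, the width reflecting the single precedent and the wide gap separating the two cores.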

Compound 4, half-maximal inhibitory concentration: 38800 nM
Estimate against measurement, compound 4: 1.1-fold (0.06 log units) below, and the stated range covers the measured number.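

On the core of compound 1, azido in place of chloro gave a 1.7-fold higher number from compound 1 to compound 4 (0.24 log units; within the scatter) in this assay, so on this core the two groups cannot be told apart in this read-out. Set beside the same change on the core of compound 2, the step is of the same size, and the two cores respond alike within what repeated measurements can resolve: the same change on two cores in this assay, a 1.6-fold higher number (0.21 log units; within the scatter) from compound 2 to compound 3 and a 1.7-fold higher number (0.24 log units; within the scatter) from compound 1 to compound 4, 1.1-fold (0.02 log units) apart, within the scatter of two such steps

This shows that, for these two cores and this one cell assay, the chloro-to-azido change carried over from one core to the other, and that the step seen on one core was a fair guide to the step on the other; it does not show why the two groups read alike, nor that the same would hold on a third core or in a different assay.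

The compounds shown leave open how an amine or a bromo group would read in this assay at the same place, on a saturated chain carbon bound to a carbonyl carbon, on either core. They also leave open whether a longer chain carrying the azido group would behave like the azidomethyl group seen here.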